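This account rests on a few compounds, and the source may have more. Where it says the series, first, only, none or still open, it means among the compounds named here.

In a functional assay on NCI-H23 cells (Homo sapiens) for cytotoxicity, read by sulforhodamine B assay, with a stated time of 72 h (a lower number here means a stronger inhibitor of growth, a higher number a weaker inhibitor of growth), three compounds have been run. Compound 2 `O=C(Nc1ccc(C(F)(F)F)cc1)C1CCc2ccccc2N1` gives 25800 nM, the higher of the two numbers shown, while compound 3 `O=C(Nc1ccccc1C(F)(F)F)C1CCc2ccccc2N1C(=O)c1cccc(Cl)c1` gives 292 nM. Compound 1 `O=C(Nc1ccccc1C(F)(F)F)c1ccc2ccccc2n1` gives > 90000 nM, a limit of the assay rather than a number, namely (the limit of > 90000 nM in this assay, at which 1 of the 3 values shown sits). Compound 4 `O=C(Nc1ccccc1)C1CCc2ccccc2N1` has not yet been measured in this assay. Set beside compound 2, it carries hydrogen in place of trifluoromethyl on an aromatic carbon, the change sitting on an aromatic carbon of a six-membered aromatic ring of carbon only, para to a large group. For the measured compounds named here, no step between two measured compounds is available to guide this change. A modest weakening is expected, the step of a 1.7-fold higher number from compound 2 to compound 4 (0.24 log units; within the scatter) lying close to the scatter. Compound 4 is therefore estimated at 45000 nM, with a range from 15000 nM to 120000 nM.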

Compound 4, concentration for 50% growth inhibition: 97100 nM
Estimate against measurement, compound 4: 2.2-fold (0.33 log units) below; the measured number falls inside the stated range.
By their numbers in this assay, from the lowest: compound 3; then compound 2; then compound 4.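

The first step read at this position shows that the trifluoromethyl para to a large group counts in this assay: replaced by hydrogen, it gives a 3.8-fold higher number from compound 2 to compound 4 (0.58 log units; beyond the scatter), a modest change but beyond the usual scatter. Without that group, compound 4 reads close to where the assay stops giving numbers, the mark that compound 1 carries as a limit: the limit of > 90000 nM in this assay, at which 1 of the 4 values shown sits.

Going by these compounds, what chlorine, a methoxy group or a nitrile would do on this aromatic carbon stays open. The compounds shown also leave open why trifluoromethyl has this effect.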